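The source may report more compounds than this note shows. Statements on the series, on what has been measured and on what is new or still open speak of the compounds shown alone.

Compound 1 `Cn1c(-c2ccccc2Br)cnc1NC(=O)c1ccc(F)cc1` gives > 100000 nM in a toxicity assay on THP-1 cells (Homo sapiens) for inhibition (on this read-out higher numbers stand for lower toxicity in this test and lower numbers for higher toxicity in this test), which is a limit of the test rather than a number. Compound 2 `COc1ccc(-c2cnc(NC(=O)c3cnco3)n2C)cc1` gives > 100000 nM in this assay, again a limit. Compound 3 `Cn1c(-c2ccccc2Cl)cnc1NC(=O)c1ncc[nH]1` gives > 50000 nM in this assay, also a limit.

For compound 2 there is thus only a limit, and the same holds for the other two compounds: two of the values sit at the limit of > 100000 nM in this assay, at which 2 of the 3 values shown sit, and one at the limit of > 50000 nM in this assay, at which 1 of the 3 values shown sits. Going by the values given here, no two of the measured compounds differ in a single place, so no measured step shows how a change of one group shifts the read-out.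

Compound 4 `COc1ccc(-c2cnc(NC(=O)c3cccc(C)c3)n2C)cc1` is not yet measured. It differs from compound 2 by 3-methylphenyl in place of 1,3-oxazol-5-yl on a carbonyl carbon. With every measured value a limit, there is no ground to expect a step beyond the usual scatter in this assay in either direction. Compound 4 is therefore expected to give about 100000 nM, in a range from 50000 nM to 200000 nM. The step of a number no higher from compound 2 to compound 4 (the limit leaves the size open) is expected to stay small, with a good chance that only a limit is reported again.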

Compound 4, half-maximal cytotoxic concentration: > 100000 nM
Compound 4 ended at the assay's limit; the forecaster's own chance of this, stated with the estimate: 85%; the middle value sits exactly at the limit.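

Compound 2 and compound 4 both end at a limit in this assay rather than at a number, so the step between them cannot be read. The compounds shown leave open what concentration, if any, would produce a measurable toxic effect in this assay.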